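The compounds below may be only part of what the source reports. "The series", "measured", "known", "first", "only" and "open" are said of these compounds alone.

In an ADME assay on HEK293 cells (Homo sapiens) for antiproliferative activity, read by MTT assay, with a stated time of 48 h (a lower number here means a stronger inhibitor, a higher number a weaker inhibitor), compound 1 `O=C(/C=C/c1cn(S(=O)(=O)c2cccc3ccccc23)c2ccccc12)c1ccncc1` gives > 150000 nM as a limit of the assay. Compound 2 `CCCS(=O)(=O)n1cc(/C=C/C(=O)c2ccncc2)c2ccccc21` gives > 150000 nM as a limit as well. Compound 3 `O=C(/C=C/c1cn(S(=O)(=O)c2ccccc2[N+](=O)[O-])c2ccccc12)c1ccncc1` gives > 150000 nM as a limit too, so it stands at the limit of > 150000 nM in this assay, at which 3 of the 3 values shown sit, with no number of its own. Compound 4 `O=C(/C=C/c1cn(S(=O)(=O)c2ccc(Cl)cc2)c2ccccc12)c1ccncc1` carries 4-chlorophenyl in place of 2-nitrophenyl on a sulfonyl sulfur, and 4-chlorophenyl in place of 2-nitrophenyl on a sulfonyl sulfur gives the full count of that change. Three measured changes at this place bear on it: a step that the two limits leave unreadable from compound 1 to compound 3 and a step that the two limits leave unreadable from compound 2 to compound 3 and a step that the two limits leave unreadable from compound 1 to compound 2 offer no size to carry over. No step beyond the scatter is therefore expected in this assay for this change. The expected step is a number no higher from compound 3 to compound 4 (the limit leaves the size open) in size. Compound 4 is estimated at 150000 nM within an expected range from 70000 nM to 300000 nM. Compound 4 may again give only a limit of the assay.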

Compound 4, half-maximal inhibitory concentration: > 150000 nM
Compound 4: a limit, no number (the forecaster's own chance of this, stated with the estimate: 75%); the middle value lies on the limit itself.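

In this assay, among the compounds shown here, compound 4 gives only a limit of the assay, as do compound 1, compound 2 and compound 3, so no step among them can be read: the limit of > 150000 nM in this assay, at which 4 of the 4 values shown sit. The compounds shown leave open whether the group on the sulfonyl sulfur makes any difference in this assay.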